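Ethoxycarbonyl Replaces Propyl on an Amide Carbonyl

This account rests on a few compounds, and the source may have more. Where it says the series, first, only, none or still open, it means among the compounds named here.

In a functional assay on U-87MG ATCC cells (Homo sapiens) for inhibition (a lower number here means a stronger inhibitor, a higher number a weaker inhibitor), compound 1 `COc1cc(/C=C/C(=O)c2cccc(N)c2)ccc1O` gives 7.71 ug/mL while compound 2 `CCCC(=O)Nc1cccc(C(=O)/C=C/c2ccc(O)c(OC)c2)c1` gives 5.56 ug/mL and these two numbers lie within the usual scatter of repeated measurements, so compound 2 cannot be ranked against compound 1. Among the measured compounds shown here, compound 3 `CCOC(=O)C(=O)Nc1cccc(C(=O)/C=C/c2ccc(O)c(OC)c2)c1` differs from compound 2 in one place, ethoxycarbonyl in place of propyl on a carbonyl carbon and no compound measured so far carries that group. For the measured compounds named here, the one measured step that bears on this is a 1.4-fold lower number from compound 1 to compound 2 (0.14 log units; within the scatter) for propylcarbonyl in place of hydrogen on a nitrogen on an aromatic ring, and it stays within the scatter. That step does not test the new swap itself, so it offers only thin guidance. On this evidence, no change beyond the scatter is expected in this assay for the new swap. The estimated step is a 1.1-fold higher number from compound 2 to compound 3 (0.03 log units; within the scatter) and it carries wide margins. Compound 3 is expected to give about 6 ug/mL with an estimated range of 2.5 ug/mL to 14 ug/mL in a repeat of this measurement.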

Compound 3, half-maximal inhibitory concentration: > 50 ug/mL
Compound 3: a limit, no number; the forecaster's own chance of this, stated with the estimate: 3%; middle value at least 8.3-fold (0.92 log units) from the limit.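

In this assay compound 3 stands at a limit of the assay and not at a number: the limit of > 50 ug/mL in this assay, at which 1 of the 3 values shown sits. Until now, the nitrogen on the aromatic ring showed no sensitivity to what it carried, since adding propylcarbonyl gave only a 1.4-fold lower number from compound 1 to compound 2 (0.14 log units; within the scatter), but replacing propyl with ethoxycarbonyl on the carbonyl carbon gives an at least 8.9-fold higher number from compound 2 to compound 3 (0.95 log units; beyond the scatter), and in this assay a higher number means a weaker inhibitor. Measured against hydrogen on the same nitrogen, (ethoxycarbonyl)carbonyl gives an at least 6.4-fold higher number from compound 1 to compound 3 (0.81 log units; beyond the scatter), so this position does not accept every group attached through a carbonyl, and the change weakens inhibition relative to both earlier compounds.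

The compounds shown do not separate the contribution of the ethoxycarbonyl's carbonyl from that of its ethyl end, and they give no reason for the weakening. Going by these compounds, it also stays open whether a carboxylic acid, a methoxycarbonyl, a simple amide or a longer chain such as pentyl on that same carbonyl carbon would stay close to compound 2 or behave like compound 3.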